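The source may report more compounds than this note shows. Statements on the series, on what has been measured and on what is new or still open speak of the compounds shown alone.

Two compounds with the same core and linker frame this question. For the measured compounds named here, in an ADME assay on L6 cells (Rattus norvegicus) for cytotoxicity, read by resazurin assay, with a stated time of 70 h (on this read-out lower numbers stand for stronger inhibition and higher numbers for weaker inhibition), compound 1 `COc1cc(NC(C)CCCNC(=O)NNC(=O)/C=C/c2ccc(OC)c(OC)c2)c2ncccc2c1` gives 37000 nM, and this is the only number available. Compound 2 `COc1cc(NC(C)CCCNC(=O)NNC(=O)NC(CO)(CO)CO)c2ncccc2c1` has the entry "not determined" (no result reported), so compound 2 has no place on the scale and offers no starting point for a measured step. The next compound to be tested is compound 3 `COc1cc(NC(C)CCCNC(=O)NNC(=O)Nc2cccc(Cl)c2)c2ncccc2c1`. The structural change is 3-chlorophenyl in place of 2-hydroxy-1,1-bis(hydroxymethyl)ethyl on an amide-type nitrogen: 3-chlorophenyl stands in place of 2-hydroxy-1,1-bis(hydroxymethyl)ethyl on an amide-type nitrogen. With no number for compound 2, the size of this step cannot be read directly. Going by the values given here, the only anchor is compound 1 at 37000 nM, and compound 3 is expected to land near it, with no clear shift beyond the usual scatter in either direction. For compound 3 the expected value is 25000 nM, with an estimated range from 6000 nM to 90000 nM.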

Compound 3, half-maximal inhibitory concentration: 58600 nM
Compound 3: the middle estimate sits 2.3-fold (0.37 log units) below what was measured; the range from low to high includes it.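

In this assay, putting (3-chlorophenyl)amino in place of 2-(3,4-dimethoxyphenyl)ethenyl on a carbonyl carbon gives a 1.6-fold higher number from compound 1 to compound 3 (0.20 log units; within the scatter), so these two aromatic groups cannot be told apart on this read-out. This second number shows that this position can carry two quite different ring-bearing groups with the shared core and linker unchanged and no shift beyond the usual scatter. The step involving compound 2 cannot be read, and nothing available here explains why compound 1 and compound 3 read alike.

From the compounds shown here alone, whether the 2-hydroxy-1,1-bis(hydroxymethyl)ethyl group of compound 2, which has no ring, would stand apart from these two remains open. So does the reading in this assay for a group such as a carboxylic acid or a longer alkyl chain at this position.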